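A Swap of Halogenated Phenyl Groups on Compound 3

The compounds below may be only part of what the source reports. "The series", "measured", "known", "first", "only" and "open" are said of these compounds alone.

In a functional assay on MCF7 cells (Homo sapiens) for inhibition, read by MTT assay, with a stated time of 48 h, tested at 10 uM (on this read-out lower numbers stand for less inhibition of growth and higher numbers for more inhibition of growth at the one concentration tested), compound 1 (`Cc1cc(=O)c2c(O)cc(OCc3ccc(Br)cc3)c([C@H]3CCN(C)C[C@H]3O)c2o1`) gives 14% and compound 2 (`Cc1cc(=O)c2c(O)c(CN3CC(O)CC3C(=O)O)c(O)c([C@H]3CCN(C)C[C@H]3O)c2o1`) gives 25% in the same test. Compound 3 (`Cc1oc2c([C@H]3CCN(C)C[C@H]3O)c(O)cc(O)c2c(=O)c1C(O)c1ccc(F)c(Br)c1`) gives 14% so it stands level with compound 1 within the scatter, and both lie clearly under compound 2. Compound 4 (`Cc1oc2c([C@H]3CCN(C)C[C@H]3O)c(O)cc(O)c2c(=O)c1C(O)c1cccc(Cl)c1Cl`) carries 2,3-dichlorophenyl in place of 3-bromo-4-fluorophenyl on a saturated chain carbon bound to an aromatic carbon and an oxygen on a saturated carbon. Among the measured compounds shown here, no two measured compounds differ in one place only, so nothing here shows directly what such a swap does. In this assay no step beyond the scatter is expected, and the estimated a number 2 percentage points higher from compound 3 to compound 4 (within the scatter) is small. Compound 4 is expected at 16% with an estimated range from 5% to 30% in this measurement.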

Compound 4, percent growth inhibition at one concentration: 7%
The estimate for compound 4 lay 9 percentage points above the measured number; the range from low to high includes it.
By their numbers in this assay, from the lowest: compounds 4, 1 and 3 (each within the scatter of the next); then compound 2.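

Putting 2,3-dichlorophenyl in place of 3-bromo-4-fluorophenyl on a saturated chain carbon bound to an aromatic carbon and an oxygen on a saturated carbon gives a number 7 percentage points lower from compound 3 to compound 4 (within the scatter) in this assay. This first comparison of compounds that differ in one place shows that these two halogenated phenyl groups cannot be told apart at this position. Nothing available offers a reason for this result. The compounds shown leave open whether an unsubstituted phenyl, an amine or a carboxylic acid at this place would read differently.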